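The source may report more compounds than this note shows. Statements on the series, on what has been measured and on what is new or still open speak of the compounds shown alone.

Working notes on the series. In an ADME assay on L02 cells (Homo sapiens) for cytotoxicity, read by MTT assay, with a stated time of 24 h (on this read-out higher numbers stand for weaker inhibition and lower numbers for stronger inhibition), compound 1 (`Cc1ccc(S(=O)(=O)N2C/C(=C\c3cccnc3)C(=O)/C(=C/c3ccccc3C(F)(F)F)C2)cc1`) gives 12300 nM and compound 2 (`Cc1ccc(S(=O)(=O)N2C/C(=C\c3ccncc3)C(=O)/C(=C/c3ccccc3C(F)(F)F)C2)cc1`) gives 12800 nM. For the measured compounds named here, the one measured step, a 1.0-fold higher number from compound 1 to compound 2 (0.02 log units; within the scatter), swaps pyridin-3-yl for pyridin-4-yl and lies within the scatter, so compound 2 stands level with compound 1.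

Compound 3 (`N#Cc1ccc(S(=O)(=O)N2C/C(=C\c3ccncc3)C(=O)/C(=C/c3ccccc3C(F)(F)F)C2)cc1`) differs from compound 2 at a single place: cyano in place of methyl on an aromatic carbon. This is cyano in place of methyl on an aromatic carbon, which reads as 4-methylphenyl to 4-cyanophenyl. Going by the values given here, the measured step bears on it only indirectly, since it concerns the pyridinyl group and no measured pair changes the 4-methylphenyl group. The data therefore give no direction for this change and no size for it. The working expectation starts from compound 2 at 12800 nM, with a wide margin for the untested change.

The expected step is a 1.1-fold lower number from compound 2 to compound 3 (0.03 log units; within the scatter), with no shift beyond the scatter anticipated. For compound 3 the estimated value is 12000 nM, with an expected range from 5000 nM to 28000 nM.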

Compound 3, half-maximal inhibitory concentration: 17600 nM
Compound 3: middle estimate off by 1.5-fold (0.17 log units), on the low side; the range from low to high includes it.
By their numbers in this assay, from the lowest: compounds 1, 2 and 3 (each within the scatter of the next).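

In this assay, for the compounds shown here, the change from 4-methylphenyl to 4-cyanophenyl gives a 1.4-fold higher number from compound 2 to compound 3 (0.14 log units; within the scatter), the first measured change at this aromatic carbon para to a large group, where the earlier compounds had varied only the pyridinyl group. Exchanging methyl for cyano here, which adds a hydrogen-bond acceptor and a triple bond, leaves compound 3 level with compound 2, so this position joins the pyridinyl position in showing no step beyond the scatter. No supporting data bear on why the two compounds read alike.

Open questions remain at this position: whether cyano in place of methyl would read the same with the pyridin-3-yl group of compound 1, and whether an amine or a carboxylic acid on this aromatic carbon would move the number beyond the scatter. As far as these compounds go, the trifluoromethyl group is constant across all three compounds, so the effect of a methoxy group or a fluorine in its place also stays open.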